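Replacing the methoxypyridinyl group in compound 1 with a chlorophenyl

The source may hold more compounds than are shown below. What is called first, only, known or untested is meant among the compounds shown, and "the series" means these compounds.

Compound 1 `COc1cncc(-c2c(C)nn(-c3nc(-c4ccc(Cl)c(Cl)c4)c(SC(C)C)s3)c2C(=O)O)c1` is the weakest of the three measured compounds in a functional assay on BJAB cells (Homo sapiens) for antiproliferative activity, with a stated time of 4 days (on this read-out higher numbers stand for an effect only at larger amounts of compound and lower numbers for an effect already at smaller amounts), where compound 1 gives 21000 nM. Two measured steps replace the same group. Compound 2 `Cc1cc(-c2c(C)nn(-c3nc(-c4ccc(Cl)c(Cl)c4)c(SC(C)C)s3)c2C(=O)O)cc(C)n1` gives 580 nM, a change of a 36-fold lower number from compound 1 to compound 2 (1.56 log units; beyond the scatter). Compound 3 `Cc1cc(C)cc(-c2c(C)nn(-c3nc(-c4ccc(Cl)c(Cl)c4)c(SC(C)C)s3)c2C(=O)O)c1` gives 2700 nM, a change of a 7.8-fold lower number from compound 1 to compound 3 (0.89 log units; beyond the scatter). Between these two alternatives the step is a 4.7-fold higher number from compound 2 to compound 3 (0.67 log units; beyond the scatter).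

Compound 4 `Cc1nn(-c2nc(-c3ccc(Cl)c(Cl)c3)c(SC(C)C)s2)c(C(=O)O)c1-c1cccc(Cl)c1` differs from compound 1 by 3-chlorophenyl in place of 5-methoxypyridin-3-yl on an aromatic carbon. Both measured replacements of the 5-methoxypyridin-3-yl group lowered the number beyond the scatter, and the entering 3-chlorophenyl, a six-membered ring of carbon only, resembles the 3,5-dimethylphenyl of compound 3 more than the 2,6-dimethylpyridin-4-yl of compound 2. A lower number is therefore expected for compound 4 in this assay, with a step of roughly a 7.0-fold lower number from compound 1 to compound 4 (0.85 log units; beyond the scatter) expected, closer in size to the step to compound 3 than to the step to compound 2. Compound 4 is estimated at 3000 nM, within a range from 800 nM to 12000 nM.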

Compound 4, half-maximal effective concentration: 13600 nM
For compound 4 the middle estimate is 4.5-fold (0.66 log units) below the measured one; measured number above the stated range.
By their numbers in this assay, from the lowest: compound 2; then compound 3; then compounds 4 and 1 (each within the scatter of the next).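

In this assay the 3-chlorophenyl group at this position gives a 1.5-fold lower number from compound 1 to compound 4 (0.19 log units; within the scatter) and so does not share the lower numbers of the two earlier replacements of 5-methoxypyridin-3-yl. A six-membered aromatic ring of carbon only is thus not enough in itself: 3-chlorophenyl in place of 3,5-dimethylphenyl gives a 5.0-fold higher number from compound 3 to compound 4 (0.70 log units; beyond the scatter) and in place of 2,6-dimethylpyridin-4-yl gives a 23-fold higher number from compound 2 to compound 4 (1.37 log units; beyond the scatter) as the larger step. Among these four compounds, the lower numbers belong to compound 2 and compound 3, the two with a dimethyl-substituted ring, while compound 1 and compound 4 have neither methyl group.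

No measurement shown here accounts for these differences. As far as these compounds go, whether a single methyl group, as in 3-methylphenyl, or a second chlorine, as in 3,5-dichlorophenyl, would move the number remains open.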